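The compounds below may be only part of what the source reports. "The series", "measured", "known", "first", "only" and "open" are said of these compounds alone.

In an assay for inhibition of sodium- and chloride-dependent glycine transporter 1 (Homo sapiens) (a lower number here means that less compound is needed, a higher number that more compound is needed for the effect), compound 2 `O=C(CNC(=O)c1ccc(F)cc1)NC(c1ccccc1)c1ccccc1` gives 110 nM, the lower of the two numbers in hand, and its step to compound 1 lies beyond the scatter. Compound 1 `N#Cc1ccc(C(=O)NCC(=O)NC(c2ccccc2)c2ccc(Cl)cc2)cc1` gives 230 nM. Compound 3 `O=C(CNC(=O)c1ccc(F)cc1)NC(c1ccccc1)c1cccc(Cl)c1` carries the change (chloro in place of hydrogen on an aromatic carbon), phenyl to 3-chlorophenyl. Among the compounds with values here, no pair of measured compounds differs by this change, so nothing measured sets its size; a shift of no more than the usual scatter, in either direction, is expected in this assay. The number for compound 3 is estimated at 100 nM, within 40 nM to 250 nM, which would mean an expected step of a 1.1-fold lower number from compound 2 to compound 3 (0.04 log units; within the scatter).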

Compound 3, half-maximal effective concentration: 33 nM
Compound 3: middle estimate off by 3.0-fold (0.48 log units), on the high side; the whole stated range lies above it.
By their numbers in this assay, from the lowest: compound 3; then compound 2; then compound 1.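

In this assay, chloro in place of hydrogen on an aromatic carbon gives a 3.3-fold lower number from compound 2 to compound 3 (0.52 log units; beyond the scatter), so this position, meta to a large group, responds to one added chlorine by more than the scatter. Compound 1 could not show this, as it differs from compound 2 in more than one place. Nothing in hand accounts for the step.

As far as these compounds go, whether fluoro, methoxy or trifluoromethyl at this position gives a similar step remains open. So does whether the 3-chlorophenyl step holds alongside the nitrile of compound 1.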